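Removing a Methyl From the Core: Measured and Expected

The compounds below may be only part of what the source reports. "The series", "measured", "known", "first", "only" and "open" are said of these compounds alone.

In a functional assay on NCI-H460 cells (Homo sapiens) (a lower number here means a stronger inhibitor of growth, a higher number a weaker inhibitor of growth), three compounds have been measured:
Compound 1 `COc1ccc(-c2cc(O)c3cccnc3n2)cc1` gives 26300 nM.
Compound 2 `COc1cccc(-c2cc(O)c3c(C)ccnc3n2)c1` gives 47.9 nM.
Compound 3 `COc1ccc(-c2cc(O)c3ccc(C)nc3n2)cc1` gives > 100000 nM, which is a limit of the assay and not a number; it is the limit of > 100000 nM in this assay, at which 1 of the 3 values shown sits.

Between compound 3 and compound 1 the change is hydrogen in place of methyl on an aromatic carbon, and it gives an at least 3.8-fold lower number from compound 3 to compound 1 (0.58 log units; beyond the scatter). Compound 2 has the lowest of the two numbers, and its nearest neighbour, compound 1, lies well beyond the scatter above it. How the core of compound 2 differs from that of compound 3 is not broken down here.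

Compound 4 `COc1cccc(-c2cc(O)c3cccnc3n2)c1` has not yet been measured. From compound 2 it differs by hydrogen in place of methyl on an aromatic carbon. This is the same kind of change as from compound 3 to compound 1, but the place differs: here the carbon is ortho to a fused ring and opposite the ring nitrogen, whereas there it was next to the ring nitrogen and para to a fused ring. Within the data shown here, with only one measured example of this kind of change, and that at another place, the expectation is loosely held: from compound 2 to compound 4 the step is expected to be a 3.1-fold higher number from compound 2 to compound 4 (0.50 log units; beyond the scatter), set beside an at least 3.8-fold lower number from compound 3 to compound 1 (0.58 log units; beyond the scatter) for comparison rather than copied from it. Compound 4 is therefore estimated at 150 nM, expected to lie between 20 nM and 2000 nM in this assay.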

Compound 4, concentration for 50% growth inhibition: 91.2 nM
Estimate against measurement, compound 4: 1.6-fold (0.22 log units) above; low and high end bracket the measured number.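

In this assay, hydrogen in place of methyl on an aromatic carbon gives a 1.9-fold higher number from compound 2 to compound 4 (0.28 log units; within the scatter), so compound 2 and compound 4 cannot be told apart, and this does not match what the same change did on the other core: the same change on two cores in this assay, an at least 3.8-fold lower number (0.58 log units; beyond the scatter) from compound 3 to compound 1 and a 1.9-fold higher number (0.28 log units; within the scatter) from compound 2 to compound 4, at least 7.2-fold (0.85 log units) apart, beyond the scatter of two such steps

This shows that the effect of the change does not simply carry over from one core to another in this series, but it does not show why, as the methyl sits at a different place in each pair, the methoxy group also sits differently, and two pairs cannot separate these differences. Compound 3 gives > 100000 nM, which is a limit of the assay and not a number.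

The compounds shown leave open how other groups would behave at the carbon opposite the ring nitrogen, for example an amine, a carboxylic acid or a longer chain such as propyl. As far as these compounds go, it also remains open how the same change would behave on further cores.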